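Adding Methoxy to the Anilide Ring of Compound 2

A few compounds are considered here, and "the series" means these few. Any claim that something is new, unique, unknown or untested is made for them only; others in the source may bear on it.

Measured in a functional assay on HCT-116 cells (Homo sapiens) for inhibition, read by colorimetric assay, with a stated time of 3 days; on this read-out lower numbers stand for stronger inhibition and higher numbers for weaker inhibition:
- compound 1 `O=C(CCCCCCNC(=O)C(O)(O)C(F)(F)F)Nc1nc2ccccc2o1`: 3450 nM
- compound 2 `O=C(CCCCCCNC(=O)C(O)(O)C(F)(F)F)Nc1ccccc1`: 9140 nM
- compound 3 `O=C(CCCCCCNC(=O)C(O)(O)C(F)(F)F)Nc1ccc(C(=O)c2ccccc2)cc1`: > 40000 nM

Of the two actual numbers, compound 2 has the higher, at 9140 nM. The value for compound 3, > 40000 nM, is a limit and not a number. Compound 4 `COc1cccc(NC(=O)CCCCCCNC(=O)C(O)(O)C(F)(F)F)c1` differs from compound 2 by methoxy in place of hydrogen on an aromatic carbon. Among the compounds with values here, the closest precedent is an at least 4.3-fold higher number from compound 2 to compound 3 (0.64 log units; beyond the scatter), where benzoyl replaces hydrogen on an aromatic carbon. The step of a 2.6-fold higher number from compound 1 to compound 2 (0.42 log units; beyond the scatter) changes the group on the amide-type nitrogen and bears on this less directly. Methoxy is the smaller group, so a weaker shift in the same direction is expected, perhaps none beyond the scatter. The expected step is a 1.1-fold higher number from compound 2 to compound 4 (0.04 log units; within the scatter). For compound 4 the estimated value is 10000 nM, with an expected range of 4000 nM to 25000 nM.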

Compound 4, half-maximal inhibitory concentration: 6110 nM
Compound 4: middle estimate off by 1.6-fold (0.21 log units), on the high side; low and high end bracket the measured number.
By their numbers in this assay, from the lowest: compounds 1, 4 and 2 (each within the scatter of the next, the first and the last beyond it). At a limit, above all of these: compound 3.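

In this assay, the anilide ring of compound 2 takes methoxy on an aromatic carbon, meta to a large group, with a step of a 1.5-fold lower number from compound 2 to compound 4 (0.17 log units; within the scatter), so a small substituent at this position is tolerated without a shift beyond the scatter. Replacing 1,3-benzoxazol-2-yl with 3-methoxyphenyl gives a 1.8-fold higher number from compound 1 to compound 4 (0.25 log units; within the scatter), so this anilide is not separated from the benzoxazole beyond the scatter. Nothing available here accounts for these steps. Still open, on these data alone, is whether a hydroxyl, an amine or a fluorine on the same carbon would behave like methoxy, and what a longer chain would do.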